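Swapping the sulfur-bound azole in the anilide series

The source may hold more compounds than are shown below. What is called first, only, known or untested is meant among the compounds shown, and "the series" means these compounds.

Going by the values given here, compound 3 `Cn1cnnc1SCC(=O)Nc1ccc(-c2nc(-c3ccccc3)c(-c3ccccc3)n2C)cc1` gives 61.2% in a functional assay on MCF7 cells (Homo sapiens) for cytotoxicity, read by MTT assay, with a stated time of 24 h, tested at 16 ug/mL (a higher number here means a stronger effect of the compound at the concentration tested, a lower number a weaker effect), the highest of the three numbers so far. Compound 1 `Cn1c(-c2ccc(NC(=O)CSc3nc4cc(Cl)ccc4o3)cc2)nc(-c2ccccc2)c1-c1ccccc1` gives 40% and compound 2 `Cc1ccc2oc(SCC(=O)Nc3ccc(-c4nc(-c5ccccc5)c(-c5ccccc5)n4C)cc3)nc2c1` gives 40.3% in this assay; their difference is a number 0.3 percentage points higher from compound 1 to compound 2 (within the scatter). What separates both from compound 3 is the group on the sulfur: a number 21.2 percentage points higher from compound 1 to compound 3 (beyond the scatter) and a number 20.9 percentage points higher from compound 2 to compound 3 (beyond the scatter). Compound 4 `Cc1nnc(SCC(=O)Nc2ccc(-c3nc(-c4ccccc4)c(-c4ccccc4)n3C)cc2)s1` carries the next change there: 5-methyl-1,3,4-thiadiazol-2-yl in place of 4-methyl-4H-1,2,4-triazol-3-yl on a sulfur. Among the compounds with values here, no measured step exchanges one small five-membered ring for another on that sulfur; the two steps seen only show that this position can shift the read-out by a modest amount, in either direction as far as these data tell. The step from compound 3 is therefore expected to be a number 9.2 percentage points lower from compound 3 to compound 4 (within the scatter), with no direction held firmly. Compound 4 is estimated at 52% in this assay, in a range from 32% to 72%.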

Compound 4, a percentage reported as activity, at one concentration (the size of the read-out at that concentration, not a potency): 74.9%
Compound 4: the middle estimate sits 22.9 percentage points below what was measured; measured number above the stated range.
By their numbers in this assay, from the lowest: compounds 1 and 2 (each within the scatter of the next); then compound 3; then compound 4.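

In this assay, exchanging one small five-membered ring for another on the sulfur is itself a step beyond the scatter, a number 13.7 percentage points higher from compound 3 to compound 4 (beyond the scatter). Measured against the two benzoxazolyl groups, 5-methyl-1,3,4-thiadiazol-2-yl gives the largest steps in the set, a number 34.6 percentage points higher from compound 2 to compound 4 (beyond the scatter) and a number 34.9 percentage points higher from compound 1 to compound 4 (beyond the scatter). No measured evidence accounts for the difference between these groups on the sulfur.

The compounds shown do not separate the ring sulfur from the shifted methyl within this change. Also open, from the compounds shown here alone, is how an amine or a carboxylic acid in place of that methyl would read.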